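The source may hold more compounds than are shown below. What is called first, only, known or untested is meant among the compounds shown, and "the series" means these compounds.

Measured compounds:
compound 1 `COc1cccc(N2C(=O)N/C(=C\c3ccc(O)cc3)C2=O)c1` — in a functional assay on NCI-H292 cells (Homo sapiens) for antiproliferative activity (on this read-out higher numbers stand for weaker inhibition and lower numbers for stronger inhibition), compound 1 gives > 200000 nM, a limit of the assay and not a number.
compound 2 `O=C1N/C(=C\c2ccc(O)cc2)C(=O)N1c1cccc(I)c1` — in this assay compound 2 gives > 200000 nM, again only a limit.
compound 3 `CCOC(=O)c1ccc(N2C(=O)N/C(=C\c3ccc(O)cc3)C2=O)cc1` — in this assay compound 3 gives > 200000 nM, likewise only a limit.

Compound 3 thus stands at the limit, as do the other two; every value shown sits there (the limit of > 200000 nM in this assay, at which 3 of the 3 values shown sit). Within the data shown here, the one step between measured compounds, a step that the two limits leave unreadable from compound 1 to compound 2, is unreadable because both ends are limits.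

Compound 4 `O=C(NCC1CCCCC1)c1ccc(N2C(=O)N/C(=C\c3ccc(O)cc3)C2=O)cc1` differs from compound 3 by (cyclohexylmethyl)amino in place of ethoxy on a carbonyl carbon. Among the measured compounds shown here, no measured step touches this part of the scaffold, so no direction can be read off. The estimated step from compound 3 to compound 4 in this assay is a step that the limit leaves unreadable from compound 3 to compound 4, none beyond the scatter. Compound 4 is therefore expected at 300000 nM, with a range from 50000 nM to 2000000 nM, most likely again reported only as a limit.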

Compound 4, half-maximal inhibitory concentration: > 200000 nM
Compound 4 ended at the assay's limit; the forecaster's own chance of this, stated with the estimate: 85%; the middle value is on the limit's open side.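

Compound 3 and compound 4 both give a limit and not a number, so no step between them can be read in this assay: the limit of > 200000 nM in this assay, at which 4 of the 4 values shown sit.

The compounds shown leave open which change to the shared core, if any, would give a readable value in this assay.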